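Taking the methyl group off compound 2

A few compounds are considered here, and "the series" means these few. Any claim that something is new, unique, unknown or untested is made for them only; others in the source may bear on it.

Measured so far:
compound 1 `Cc1ccc(C(=O)Nc2ccc(C#N)cc2)c(O)c1` gives 2560 nM
compound 2 `Cc1cccc(O)c1C(=O)Nc1ccc(C#N)cc1` gives 7940 nM

In a functional assay on KG-1 cells (Homo sapiens) for cytotoxicity, read by luminescence and CellTiter-Glo, with a stated time of 3 days (on this read-out higher numbers stand for weaker inhibition and lower numbers for stronger inhibition), compound 2 stands at the higher of the two numbers with 7940 nM and so is the weaker inhibitor of the pair. Its gap to compound 1 at 2560 nM lies beyond the usual scatter.

The next compound, compound 3 `N#Cc1ccc(NC(=O)c2ccccc2O)cc1`, has not yet been measured. It differs from compound 2 by hydrogen in place of methyl on an aromatic carbon. Within the data shown here, no step between measured compounds shows what such a change does, so the expectation rests on thin ground. Among the measured compounds shown here, with compound 1 at 2560 nM and compound 2 at 7940 nM as the only guides, a modest move toward a lower number seems likely, with compound 3 landing in the same general region. The expected change is a 1.7-fold lower number from compound 2 to compound 3 (0.22 log units; within the scatter) and it would stay within the scatter. For compound 3 the estimated value is 4800 nM with a range from 1700 nM to 13000 nM as the expected spread of a measurement.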

Compound 3, half-maximal inhibitory concentration: 5370 nM
Beside the measured number, compound 3's estimate is 1.1-fold (0.05 log units) below it, within the range that was stated.
By their numbers in this assay, from the lowest: compound 1; then compounds 3 and 2 (each within the scatter of the next).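

In this assay, the methyl group ortho to a large group and meta to a hydroxy group can give way to hydrogen with little effect on the read-out: the change gives a 1.5-fold lower number from compound 2 to compound 3 (0.17 log units; within the scatter). Among these compounds, the same replacement of a methyl group at its other place on that ring gives a 2.1-fold higher number from compound 1 to compound 3 (0.32 log units; beyond the scatter), so the unsubstituted compound has lost a modest amount of inhibition relative to that methylated analogue, and only this methyl group shows a step beyond the scatter. Nothing available explains either step, and no measurement bears on why the two methyl places read as they do.

The compounds shown test only methyl and hydrogen at the position ortho to a large group, so it remains open whether a larger or different group there, such as an amine, a methoxy group or a chlorine atom, would leave the number unchanged or shift it clearly. From the compounds shown here alone, whether a longer chain in place of the methyl group at the other place would extend the modest gain seen with methyl also remains open.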